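Swapping an ester for an azidomethyl group

The compounds below may be only part of what the source reports. "The series", "measured", "known", "first", "only" and "open" are said of these compounds alone.

Measured so far:
- compound 1, `CCc1cccc2c1nc(-c1c(F)cccc1F)n2Cc1c(F)cccc1F`: 26.1 uM
- compound 2, `COC(=O)c1cccc2c1nc(-c1c(F)cccc1F)n2Cc1c(F)cccc1F`: 57.7 uM
- compound 3, `CN(C)c1cccc2c1nc(-c1c(F)cccc1F)n2Cc1c(F)cccc1F`: > 100 uM

These three compounds share one core and differ only in a single group on an aromatic carbon. In a toxicity assay on CCRF-CEM cells (Homo sapiens) for cytotoxicity (a higher number here means that more compound is tolerated, a lower number that less compound is tolerated), compound 2 gives 57.7 uM, the highest of the two plain numbers; the nearest is compound 1, with a 2.2-fold higher number from compound 1 to compound 2 (0.34 log units; beyond the scatter). Compound 3 in this assay reaches only a limit, > 100 uM, which is the limit of > 100 uM in this assay, at which 1 of the 3 values shown sits.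

Compound 4, `[N-]=[N+]=NCc1cccc2c1nc(-c1c(F)cccc1F)n2Cc1c(F)cccc1F`, has not been measured yet. It differs from compound 2 by azidomethyl in place of methoxycarbonyl on an aromatic carbon. For the measured compounds named here, two measured steps touch the methoxycarbonyl group: a 2.2-fold higher number from compound 1 to compound 2 (0.34 log units; beyond the scatter) and an at least 1.7-fold higher number from compound 2 to compound 3 (0.23 log units; that floor lies within the scatter). Both changes at this position moved the number only modestly, and the second step has a floor within the scatter. Going by the values given here, no measured step involves an azidomethyl group, so the expectation for compound 4 is a step of no size beyond the scatter. The expected step is a 1.3-fold lower number from compound 2 to compound 4 (0.11 log units; within the scatter). Compound 4 is therefore estimated to give 45 uM in this assay, between 20 uM and 100 uM.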

Compound 4, half-maximal toxic concentration: > 100 uM
Compound 4: a limit, no number; the forecaster's own chance of this, stated with the estimate: 15%; middle value at least 2.2-fold (0.34 log units) away from the limit.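

In this assay, azido in place of methyl on the saturated chain carbon gives an at least 3.8-fold higher number from compound 1 to compound 4 (0.58 log units; beyond the scatter), so a change at that one spot of the ethyl group is enough to move the number beyond the scatter. Against the methoxycarbonyl group the result is less clear: the step is an at least 1.7-fold higher number from compound 2 to compound 4 (0.23 log units; that floor lies within the scatter), so azidomethyl cannot yet be said to be better tolerated than the ester. Compound 3 and compound 4 both end at a limit, so the step between them cannot be read: the limit of > 100 uM in this assay, at which 2 of the 4 values shown sit.

Going by these compounds, how far compound 3 and compound 4 really lie beyond that limit stays open, and with it any order between dimethylamino and azidomethyl. Also open, on these data alone, is how a carboxylic acid, a primary amine or a propyl chain on this aromatic carbon would fare.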